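The source may hold more compounds than are shown below. What is called first, only, known or untested is meant among the compounds shown, and "the series" means these compounds.

Compound 1, `COc1nc(-c2ccc(C#N)cc2)ccc1[C@@H](c1ccccc1)[C@@](O)(CCN(C)C)c1cccc2ccccc12`, in a toxicity assay on HeLa cells (Homo sapiens) for cytotoxicity (on this read-out higher numbers stand for lower toxicity in this test and lower numbers for higher toxicity in this test), gives > 64 ug/mL, which is a limit of the assay rather than a number.
Compound 2, `COc1ncc(-c2ccccc2)cc1[C@@H](c1ccccc1)[C@@](O)(CCN(C)C)c1cccc2ccccc12`, in this assay gives 30.4 ug/mL.

Of the two measured compounds, only compound 2 yields a number in this assay. For compound 1 the read-out reaches only a limit: the limit of > 64 ug/mL in this assay, at which 1 of the 2 values shown sits. For the measured compounds named here, the two compounds differ from each other in more than one place, so the pair gives no single step to follow; the values show one compound at the limit and the other at a measured concentration inside the range of the assay.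

Compound 3, `COc1nc(-c2cnsc2)ccc1[C@@H](c1ccccc1)[C@@](O)(CCN(C)C)c1cccc2ccccc12`, is reached from compound 1 by a single change: 1,2-thiazol-4-yl in place of 4-cyanophenyl on an aromatic carbon. Going by the values given here, with no measured step of this kind available, the account must rest on compound 1 alone. The step from compound 1 to compound 3 is expected to be small, an at least 1.2-fold lower number from compound 1 to compound 3 (0.10 log units; that floor lies within the scatter), and in this assay compound 3 is expected to sit near or at the limit again. The estimate for compound 3 is 50 ug/mL, within a range from 20 ug/mL to 64 ug/mL.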

Compound 3, half-maximal cytotoxic concentration: 28.8 ug/mL
Compound 3: middle estimate off by 1.7-fold (0.24 log units), on the high side; the range from low to high includes it.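

Putting 1,2-thiazol-4-yl in place of 4-cyanophenyl, on the aromatic carbon next to the ring nitrogen, gives an at least 2.2-fold lower number from compound 1 to compound 3 (0.34 log units; beyond the scatter) in this assay. This shows that the group at this place bears on the read-out, and that a change here can bring a compound from the limit to a measured concentration inside the range of the assay, which compound 1 alone could not show. Compound 1 gives > 64 ug/mL, which is a limit and not a number, so the step is known only as a floor and its full size stays unknown: the limit of > 64 ug/mL in this assay, at which 1 of the 3 values shown sits.

The change replaces a six-membered aromatic ring of carbon only, carrying a nitrile, with a five-membered aromatic ring with 2 hetero atoms, so the compounds shown cannot tell whether the nitrile, the ring size or the sulfur goes with the lower number. As far as these compounds go, it also stays open whether a morpholine at this place, or an amine or a carboxylic acid in place of the nitrile, would sit at the limit or inside the range of the assay.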